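The compounds below may be only part of what the source reports. "The series", "measured", "known", "first", "only" and "open" are said of these compounds alone.

Three compounds have been measured in an ADME assay on MT4 cells (Homo sapiens) for cytotoxicity, read by MTT assay, with a stated time of 4 days; a lower number here means that less compound is tolerated, a higher number that more compound is tolerated:

compound 1 `CCNc1nc(Nc2ccc(C#N)cc2)nc(Oc2ccc(Cl)c3ccccc23)n1`, 208000 nM;
compound 2 `CCCNc1nc(Nc2ccc(C#N)cc2)nc(Oc2ccc(Cl)c3ccccc23)n1`, 182000 nM;
compound 3 `CCNc1nc(Nc2ccc(C#N)cc2)nc(Oc2ccc3ccccc3c2Cl)n1`, 188000 nM.

Compound 1 and compound 2 share one core and differ by methyl in place of hydrogen on a saturated chain carbon, two bonds along the chain from a nitrogen on an aromatic ring. That change gave a 1.1-fold lower number from compound 1 to compound 2 (0.06 log units; within the scatter). Compound 3 carries a core made of the same atoms joined differently; the difference between the two cores is not broken down here. In this assay compound 3 gives 188000 nM, which sits within the scatter of compound 1 and compound 2.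

Compound 4 `CCCNc1nc(Nc2ccc(C#N)cc2)nc(Oc2ccc3ccccc3c2Cl)n1` has not yet been measured. It differs from compound 3 by methyl in place of hydrogen on a saturated chain carbon, two bonds along the chain from a nitrogen on an aromatic ring, the same change, at the same place, that separates compound 1 from compound 2. The step from compound 3 to compound 4 is expected to be about as small, a 1.1-fold lower number from compound 3 to compound 4 (0.04 log units; within the scatter), because a 1.1-fold lower number from compound 1 to compound 2 (0.06 log units; within the scatter) stayed within the scatter. Compound 4 is therefore expected to give about 170000 nM in this assay, most likely between 100000 nM and 300000 nM.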

Compound 4, half-maximal cytotoxic concentration: > 290000 nM
Compound 4: no number, only a limit (the forecaster's own chance of this, stated with the estimate: 15%); middle value at least 1.7-fold (0.23 log units) from the limit.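

In this assay compound 4 gives only a limit of the assay and not a number: the limit of > 290000 nM in this assay, at which 1 of the 4 values shown sits.

Read as a step, the change from ethylamino to propylamino gives an at least 1.5-fold higher number from compound 3 to compound 4 (0.18 log units; that floor lies within the scatter). This does not show that the change carries over unaltered from one core to the other, and it does not show that the two cores respond differently: the same change on two cores in this assay, a 1.1-fold lower number (0.06 log units; within the scatter) from compound 1 to compound 2 and an at least 1.5-fold higher number (0.18 log units; that floor lies within the scatter) from compound 3 to compound 4; the limit leaves it open whether they differ

The compounds shown leave open how far the true value of compound 4 lies from its limit, and so how large the step on this core really is. They also leave open how a longer chain, such as butylamino, would read on either core in this assay.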